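A few compounds are considered here, and "the series" means these few. Any claim that something is new, unique, unknown or untested is made for them only; others in the source may bear on it.

Compound 1 `COc1cc(-c2nn(-c3cccc(NC(=O)c4ccc(Cl)c(C(F)(F)F)c4)c3)cc2-c2ccncc2)ccc1Cl` gives in a functional assay on SF-295 cells (Homo sapiens) for inhibition, read by sulforhodamine B assay, with a stated time of 48 h; on this read-out higher numbers stand for lower toxicity in this test and lower numbers for higher toxicity in this test > 32500 nM, which is a limit of the assay rather than a number.
Compound 2 `COc1cc(-c2nn(-c3cccc(NC(=O)Nc4cccc(C(F)(F)F)c4)c3)cc2-c2ccncc2)ccc1Cl` gives in this assay 3200 nM.
Compound 3 `COc1cc(-c2nn(-c3cccc(NC(=O)Nc4ccc(Cl)c(C(F)(F)F)c4)c3)cc2-c2ccncc2)ccc1Cl` gives in this assay 14900 nM.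

Among the two numbers, compound 3 stands highest: a 4.7-fold higher number from compound 2 to compound 3 (0.67 log units; beyond the scatter), the change being chloro in place of hydrogen on an aromatic carbon. Compound 1 sits at a limit (the limit of > 32500 nM in this assay, at which 1 of the 3 values shown sits). From there, an at least 10-fold lower number from compound 1 to compound 2 (1.00 log units; beyond the scatter) and an at least 2.1-fold lower number from compound 1 to compound 3 (0.33 log units; beyond the scatter). Compound 4 `O=C(Nc1cccc(-n2cc(-c3ccncc3)c(-c3ccc(Cl)c(O)c3)n2)c1)Nc1ccc(Cl)c(C(F)(F)F)c1` differs from compound 3 by hydrogen in place of methyl on an oxygen on an aromatic ring. Among the measured compounds shown here, none of the three measured steps touches this oxygen; all concern the other end of the shared core, so they offer no precedent for this change. Lacking any guide, compound 4 is expected to stay near compound 3, with a 1.0-fold higher number from compound 3 to compound 4 (0.00 log units; within the scatter) within the scatter. The estimate for compound 4 is 15000 nM, ranging from 5000 nM to 45000 nM.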

Compound 4, concentration lethal to 50% of the cells: > 32500 nM
Compound 4 ended at the assay's limit; the forecaster's own chance of this, stated with the estimate: 15%; middle value at least 2.1-fold (0.33 log units) from the limit.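

Swapping methoxy for hydroxy is the first change shown at this end of the shared core, and in this assay it gives an at least 2.1-fold higher number from compound 3 to compound 4 (0.33 log units; beyond the scatter). This oxygen's substituent therefore affects the read-out, with the hydroxy compound showing lower toxicity in this test. Compound 4 sits at a limit rather than a true number, so the full size of the step stays unknown: the limit of > 32500 nM in this assay, at which 2 of the 4 values shown sit.

As far as these compounds go, whether an ethoxy group or an amine here would read like methoxy or like hydroxy stays open. So does whether the same swap would shift compound 2 to a similar extent.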